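The source may hold more compounds than are shown below. What is called first, only, known or untested is meant among the compounds shown, and "the series" means these compounds.

Compound 1 `NC(=O)c1cc(Cl)ccc1NC(=O)/C=C/c1ccccc1Br`: 10000 nM
Compound 2 `NC(=O)c1cc(Cl)ccc1NC(=O)/C=C/c1cccc(Br)c1`: this is a limit of the assay, > 10000 nM
Compound 3 `NC(=O)c1cc(Br)ccc1NC(=O)/C=C/c1ccccc1Br`: this is a limit of the assay, > 10000 nM

Three compounds were measured in a functional assay on K562 cells (Homo sapiens) for inhibition, read by trypan blue exclusion, with a stated time of 48 h; on this read-out lower numbers stand for stronger inhibition and higher numbers for weaker inhibition. Only compound 1 returns a number in this assay, 10000 nM. For compound 2 the read-out in this assay is a limit, > 10000 nM. For compound 3 the read-out in this assay is likewise a limit, > 10000 nM. The change 3-bromophenyl in place of 2-bromophenyl on a double-bonded chain carbon bound to a double-bonded chain carbon gives a number no lower from compound 1 to compound 2 (the limit leaves the size open), and the change bromo in place of chloro on an aromatic carbon gives a number no lower from compound 1 to compound 3 (the limit leaves the size open). Both steps end at the limit of > 10000 nM in this assay, at which 2 of the 3 values shown sit, so their size cannot be read.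

Compound 4 `NC(=O)c1cc(Br)ccc1NC(=O)/C=C/c1cccc(Br)c1` has not been measured. It differs from compound 3 by 3-bromophenyl in place of 2-bromophenyl on a double-bonded chain carbon bound to a double-bonded chain carbon, the same change as that from compound 1 to compound 2. The two cores differ by bromo in place of chloro on an aromatic carbon. Since compound 3 stands at the limit > 10000 nM and the same change did not lower the number in a number no lower from compound 1 to compound 2 (the limit leaves the size open), compound 4 is expected to return about 20000 nM in this assay, between 8000 nM and 60000 nM, and most likely only as a limit. The expected step is a step that the limit leaves unreadable from compound 3 to compound 4.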

Compound 4, half-maximal inhibitory concentration: > 10000 nM
Compound 4 gave a limit, no number; the forecaster's own chance of this, stated with the estimate: 85%; the middle value does not contradict the limit.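

In this assay compound 4 gives > 10000 nM as a limit and not as a number. The steps to compound 4 from compound 3 and from compound 2 cannot be read, because all three compounds stand at the same limit: the limit of > 10000 nM in this assay, at which 3 of the 4 values shown sit. Going by these compounds, it remains open how far compound 2, compound 3 and compound 4 lie from compound 1.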